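The source may hold more compounds than are shown below. What is called first, only, known or untested is meant among the compounds shown, and "the series" means these compounds.

In a functional assay on the whole organism (strain Wister albino) for inhibition, with Rattus norvegicus as the target, read by paw edema, with a stated time of 1 h, at a dose of 50 mg/kg by the intraperitoneal route (on this read-out lower numbers stand for less inhibition and higher numbers for more inhibition at the one dose given (going by the name of the read-out)), compound 1 `Cc1ccc([C@@H]2CN(C)[C@]3(C(=O)Nc4ccccc43)[C@]23Cc2ccccc2C3=O)cc1` gives 56.4%, compound 3 `CN1C[C@@H](c2cccs2)[C@@]2(Cc3ccccc3C2=O)[C@@]12C(=O)Nc1ccccc12` gives 49.9%, and compound 2 `CN1C(=O)[C@@]2(c3ccccc31)N(C)C[C@@H](c1ccco1)[C@@]21Cc2ccccc2C1=O` gives 50.1%. Compound 2 thus stands second of the three numbers, closest to compound 3 and furthest from compound 1, with both gaps within the scatter. Compound 4 `COc1ccc([C@@H]2CN(C)[C@]3(C(=O)N(C)c4ccccc43)[C@]23Cc2ccccc2C3=O)cc1` differs from compound 2 in one place: 4-methoxyphenyl in place of furan-2-yl on a saturated ring carbon. Among the measured compounds shown here, the one measured step of a comparable kind is a number 6.5 percentage points lower from compound 1 to compound 3 (within the scatter), a swap of a six-membered carbon ring for a five-membered heteroaromatic ring on the same saturated ring carbon that stayed within the scatter. The reverse kind of swap here is therefore expected to give only a small rise, not beyond the scatter, as a number 3.9 percentage points higher from compound 2 to compound 4 (within the scatter). Compound 4 is expected to reach about 54%, between 45% and 63%.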

Compound 4, a percentage reported as inhibition, in the whole organism at one dose (the size of the read-out at that dose, not a potency): 46.9%
The estimate for compound 4 lay 7.1 percentage points above the measured number; measured number inside the range.
By their numbers in this assay, from the lowest: compounds 4, 3, 2 and 1 (each within the scatter of the next).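

In this assay the 4-methoxyphenyl group, with more heavy atoms than furan-2-yl, gives a number 3.2 percentage points lower from compound 2 to compound 4 (within the scatter) on the saturated ring carbon, so this swap leaves the read-out within the scatter. Among the compounds shown here, with a number 6.5 percentage points lower from compound 1 to compound 3 (within the scatter) as the only other step at this carbon, two swaps between a five-membered heteroaromatic ring and a six-membered carbon ring have now stayed within the scatter, each on its own core. No measurement on hand bears on the reason for this result. Still open, from the compounds shown here alone, is whether a group of another kind on this carbon, such as an aminomethyl group or a carboxylic acid, would move this assay beyond the scatter.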